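From propoxy to 2-(methylsulfanyl)ethoxy on compound 3

The source may report more compounds than this note shows. Statements on the series, on what has been measured and on what is new or still open speak of the compounds shown alone.

- compound 1 `O=c1cc(N2CCNCC2)oc2ccccc12`: 240000 nM
- compound 2 `O=c1cc(N2CCNCC2)c2c(OCc3ccccc3)cccc2o1`: 429000 nM
- compound 3 `CCCOc1ccc2c(N3CCNCC3)cc(=O)oc2c1C`: 7770 nM

All three values come from a functional assay on a cell-free system (plasma, Homo sapiens) for inhibition, with Plasma (Rattus norvegicus) as the target; on this read-out lower numbers stand for stronger inhibition and higher numbers for weaker inhibition. Compound 3 stands lowest at 7770 nM, and its gaps to the other two lie beyond the scatter. Compound 4 `CSCCOc1ccc2c(N3CCNCC3)cc(=O)oc2c1C` changes only the end of its chain, with methylsulfanyl in place of methyl on a saturated chain carbon, two bonds along the chain from an oxygen on an aromatic ring. Put another way, propoxy becomes 2-(methylsulfanyl)ethoxy. For the measured compounds named here, no measured pair shows what such a change does, so the expectation starts from compound 3 at 7770 nM. The expected step is small, a 1.1-fold lower number from compound 3 to compound 4 (0.05 log units; within the scatter), with no change beyond the scatter and no firm direction. For compound 4 the estimated value is 7000 nM, within an expected range of 2500 nM to 20000 nM.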

Compound 4, half-maximal inhibitory concentration: 1500 nM
Compound 4: middle estimate off by 4.7-fold (0.67 log units), on the high side; the whole stated range lies above it.
By their numbers in this assay, from the lowest: compound 4; then compound 3; then compounds 1 and 2 (each within the scatter of the next).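

In this assay, the far end of the chain proves to matter: replacing methyl with methylsulfanyl, which turns propoxy into 2-(methylsulfanyl)ethoxy, gives a 5.2-fold lower number from compound 3 to compound 4 (0.71 log units; beyond the scatter). For the compounds shown here, the earlier compounds differ from one another in more than one place, so this pair is the first to isolate a single change. Nothing measured here explains the lower number.

As far as these compounds go, whether sulfur itself matters remains open. A 2-methoxyethoxy chain or a plain butoxy chain would help separate the effect of the atom from that of chain length.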